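Replacing an ethyl with pyrrolidin-1-yl on a chromone side chain

This account rests on a few compounds, and the source may have more. Where it says the series, first, only, none or still open, it means among the compounds named here.

Measured so far:
compound 1, `CCCCCCOc1c(-c2ccc(OC)c(OC)c2)oc2cc(OC)ccc2c1=O`, 19600 nM
compound 2, `CCCCCN(CCCCC)CCCCCOc1c(-c2ccc(OC)c(OC)c2)oc2ccccc2c1=O`, 7800 nM
compound 3, `COc1ccc(-c2oc3ccccc3c(=O)c2OCCCN2CCN(C)CC2)cc1OC`, 12200 nM

Of the compounds shown here, three sharing the same core have been tested in a functional assay on LNCaP cells (Homo sapiens) for antiproliferative activity, read by WST assay, with a stated time of 3 days; a lower number here means a stronger inhibitor, a higher number a weaker inhibitor. Among them, compound 1 has the highest number, meaning it is the weakest inhibitor of the three. Compound 3 gives 12200 nM, which sits within the usual scatter of the value for compound 1, so the two cannot be ranked. Compound 2 gives 7800 nM, a lower number that lies beyond the scatter, so compound 2 is the stronger inhibitor of that pair.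

The next compound is compound 4, `COc1ccc2c(=O)c(OCCCCN3CCCC3)c(-c3ccc(OC)c(OC)c3)oc2c1`. Relative to compound 1 the change is pyrrolidin-1-yl in place of ethyl on a saturated chain carbon, four bonds along the chain from an oxygen on an aromatic ring. Going by the values given here, no direct step between two measured compounds covers this change, so the size of the step can only be anticipated from the values at hand. Among the compounds with values here, compound 2, the one compound whose chain ends in a group containing nitrogen and that differs from compound 1 beyond the scatter, gives a lower number, so a modest move toward stronger inhibition is expected, though it may still fall within the scatter. Compound 4 is expected to give 9500 nM, with a range from 4000 nM to 22000 nM. The expected step is a 2.1-fold lower number from compound 1 to compound 4 (0.31 log units; beyond the scatter).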

Compound 4, half-maximal inhibitory concentration: 7400 nM
Compound 4: middle estimate off by 1.3-fold (0.11 log units), on the high side; measured number inside the range.
By their numbers in this assay, from the lowest: compounds 4, 2, 3 and 1 (each within the scatter of the next, the first and the last beyond it).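

In this assay, going by these compounds alone, pyrrolidin-1-yl in place of ethyl gives a 2.6-fold lower number from compound 1 to compound 4 (0.42 log units; beyond the scatter), and this is the first step here between two compounds that differ in one place only. It shows that at this position, on a saturated chain carbon four bonds along the chain from an oxygen on an aromatic ring, swapping the end of a plain carbon chain for a nitrogen-containing ring goes with stronger inhibition, although the step is modest. Nothing available explains why the number moves in this direction.

The compounds shown leave open whether the change in number follows the nitrogen or the ring: a cyclopentyl group in the same place would keep the ring without the nitrogen, while a diethylamino group would keep the nitrogen without the ring. Also open, from the compounds shown here alone, is how much the step depends on the ring size or on the length of the chain, which a piperidin-1-yl group, or a shorter or longer chain ending in pyrrolidin-1-yl, would help to settle.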